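The compounds below may be only part of what the source reports. "The series", "measured", "known", "first", "only" and "open" are said of these compounds alone.

Measured so far in a functional assay on SMMC-7721 cells (Homo sapiens) for inhibition, read by CCK-8 assay, with a stated time of 72 h, tested at 8 uM; on this read-out lower numbers stand for less inhibition of growth and higher numbers for more inhibition of growth at the one concentration tested:

compound 1 `COc1ccc(SCc2ccc(/C=C/C(=O)Nc3ccccc3N)cc2)cc1OC` gives 44.6%
compound 2 `Cc1ccc(SCc2ccc(/C=C/C(=O)Nc3ccccc3N)cc2)cc1` gives 22.2%
compound 3 `Cc1ccc(SCc2ccc(C(=O)Nc3ccccc3N)cc2)cc1` gives 82.7%

Compound 1 stands second highest of the three numbers. Its nearest neighbour is compound 2, reached by the step of a number 22.4 percentage points lower from compound 1 to compound 2 (beyond the scatter). Compound 3, which has no listed step to compound 1, sits furthest away on the numbers, and the values of compound 2 and compound 3 show compound 3 well above compound 2.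

Compound 4 `Nc1ccccc1NC(=O)/C=C/c1ccc(CSCCc2ccccc2)cc1` has not been measured. It differs from compound 1 as follows: phenethyl in place of 3,4-dimethoxyphenyl on a sulfur. Among the compounds with values here, the one measured step that bears on this change is a number 22.4 percentage points lower from compound 1 to compound 2 (beyond the scatter), where the 3,4-dimethoxyphenyl on the sulfur was also exchanged, there for a 4-methylphenyl. Both changes remove the same group from the same place and replace it with a group of one six-membered aromatic ring of carbon only and no hydrogen-bond acceptors. On that basis a step in the same direction, downward, of modest size beyond the scatter is expected for compound 4 in this assay. The number for compound 4 is estimated at 25%, with a range from 10% to 45%. The estimate for compound 4 means an expected step of a number 19.6 percentage points lower from compound 1 to compound 4 (beyond the scatter).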

Compound 4, percent growth inhibition at one concentration: 15.8%
For compound 4 the middle estimate is 9.2 percentage points above the measured one; measured number inside the range.
By their numbers in this assay, from the lowest: compounds 4 and 2 (each within the scatter of the next); then compound 1; then compound 3.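

On a sulfur whose other neighbours are saturated chain carbon, this assay now shows a second replacement for 3,4-dimethoxyphenyl, and phenethyl also goes down (a number 28.8 percentage points lower from compound 1 to compound 4 (beyond the scatter)). The drop therefore does not belong to 4-methylphenyl alone, and it appears with a group that places a saturated chain between the sulfur and the six-membered aromatic ring. Phenethyl and 4-methylphenyl do not separate in this assay (a number 6.4 percentage points lower from compound 2 to compound 4 (within the scatter)), so among compounds 1, 2 and 4 only the 3,4-dimethoxyphenyl compound stands apart, and nothing measured here explains why.

Open is which part of 3,4-dimethoxyphenyl goes with the higher number, since neither a single methoxy group on the ring, as in 4-methoxyphenyl, nor a dimethoxy-substituted phenethyl appears among the compounds shown. Also open, going by these compounds, is whether the same order of groups on the sulfur holds on the core of compound 3, where only 4-methylphenyl is present, and whether an amine or a carboxylic acid at this position would move the number at all.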